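Working notes: cyano to methyl in the series

The compounds below may be only part of what the source reports. "The series", "measured", "known", "first", "only" and "open" are said of these compounds alone.

- Compound 1 `C[C@@H](c1c[nH]c2ncccc12)c1nnc2ccc(-c3cnn(C)c3)nn12` gives 150000 nM
- Compound 2 `C[C@@H](c1ccc2ncccc2c1)c1nnc2ccc(-c3cccc(C#N)c3)nn12` gives 32500 nM
- Compound 3 `CN(C)c1ccc2nnc(Cc3ccc4ncccc4c3)n2n1` gives 134000 nM

In a physicochemical assay for solubility, measured as kinetic solubility, at pH 6.5 (on this read-out lower numbers stand for lower solubility and higher numbers for higher solubility), compound 2 has the lowest of the three numbers (32500 nM), and compound 3 and compound 1 both stand higher by more than the scatter. Compound 4 `Cc1cccc(-c2ccc3nnc([C@@H](C)c4ccc5ncccc5c4)n3n2)c1` departs from compound 2 in one place, with methyl in place of cyano on an aromatic carbon, that is 3-cyanophenyl to 3-methylphenyl. Among the compounds with values here, no measured pair shows a single change, so the expectation in this assay rests on compound 2 (32500 nM) and the structural change alone. A modest move to a lower number is expected (a 2.3-fold lower number from compound 2 to compound 4 (0.37 log units; beyond the scatter)). Compound 4 is estimated at 14000 nM (4000 nM to 45000 nM).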

Compound 4, solubility: 19000 nM
For compound 4 the middle estimate is 1.4-fold (0.13 log units) below the measured one; low and high end bracket the measured number.
By their numbers in this assay, from the lowest: compounds 4 and 2 (each within the scatter of the next); then compounds 3 and 1 (each within the scatter of the next).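

This position now has its first single-change pair: in this assay the swap of 3-cyanophenyl for 3-methylphenyl gives a 1.7-fold lower number from compound 2 to compound 4 (0.23 log units; within the scatter) and so cannot be told apart from repeat measurement. On this pair, the hydrogen-bond acceptor of the cyano group can leave this aromatic carbon without a step beyond the scatter. Nothing at hand explains why the two numbers sit this close.

As far as these compounds go, whether an amine or a carboxylic acid at this place would move the read-out beyond the scatter remains open. Also open, from the compounds shown here alone, is whether this step carries over to other cores.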